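Swapping the Chalcone's Aryl End: Methoxyphenyl to Chlorophenyl

The source may hold more compounds than are shown below. What is called first, only, known or untested is meant among the compounds shown, and "the series" means these compounds.

Of the compounds shown here, three sharing one chalcone-type core have been measured in an assay on A549 cells for inhibition of transcription factor p65 (Homo sapiens), read by fluorescence, with a stated time of 2 h; on this read-out lower numbers stand for stronger inhibition and higher numbers for weaker inhibition. Compound 1 `COc1cc(/C=C/C(=O)c2ccc(N)c(-c3ccc(F)cc3)c2)ccc1O` gives 6830 nM, compound 2 `COc1cccc(/C=C/C(=O)c2cccc(-c3cccc(F)c3)c2)c1OC` gives 24100 nM, and compound 3 `COc1ccccc1/C=C/C(=O)c1cccc(-c2cccc(F)c2)c1` gives 35300 nM. Compound 3 therefore has the highest number of the three, though its gap to compound 2 lies within the scatter; only compound 1, which differs from it in several places at once, stands clearly apart.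

Within the data shown here, the one single-point step recorded, a 1.5-fold higher number from compound 2 to compound 3 (0.17 log units; within the scatter), removed a methoxy from an aromatic carbon and changed nothing beyond the scatter.

Compound 4 `O=C(/C=C/c1ccc(Cl)cc1)c1cccc(-c2cccc(F)c2)c1` differs from compound 3 by 4-chlorophenyl in place of 2-methoxyphenyl on a double-bonded chain carbon bound to a double-bonded chain carbon. Among the measured compounds shown here, no measured pair covers this exchange of one aryl group for another; the only step on record touched a substituent on that same ring and was flat. On that thin basis, compound 4 is expected to sit close to compound 3 in this assay, with a step of a 1.2-fold lower number from compound 3 to compound 4 (0.07 log units; within the scatter) in either direction not excluded. The estimate for compound 4 is 30000 nM, within a range from 10000 nM to 90000 nM.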

Compound 4, half-maximal inhibitory concentration: 24400 nM
Compound 4: the middle estimate sits 1.2-fold (0.09 log units) above what was measured; measured number inside the range.
By their numbers in this assay, from the lowest: compound 1; then compounds 2, 4 and 3 (each within the scatter of the next).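

Replacing the whole aryl group on a double-bonded chain carbon bound to a double-bonded chain carbon, with 4-chlorophenyl in place of 2-methoxyphenyl, gives a 1.4-fold lower number from compound 3 to compound 4 (0.16 log units; within the scatter) in this assay. The earlier step removed only a methoxy from this ring, whereas here the entire group is exchanged: the group that leaves carries 1 hydrogen-bond acceptor, the one that enters carries 0 and brings a chlorine, and the number still moves by no more than the scatter. No measurement is available that would explain this result.

The compounds shown leave open whether an aryl group carrying an amine or a carboxylic acid at this place would move the number beyond the scatter. They also leave open whether a cyclohexyl group or an open alkyl chain could replace the aryl group with the number staying level.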